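The compounds below may be only part of what the source reports. "The series", "measured", "known", "first", "only" and "open" are said of these compounds alone.

Measured so far:
- compound 1, `COc1ccc(N(C)c2nc(C)nc3ccccc23)cc1C(=O)OCC[Se]C#N`: 2390 nM
- compound 2, `Cc1nc(N(C)c2ccc([Se]C#N)c(F)c2)c2ccccc2n1`: 8 nM

Notes on the series. In a functional assay on RKO cells (Homo sapiens) for inhibition, read by MTT assay, with a stated time of 48 h (a higher number here means a weaker inhibitor, a lower number a stronger inhibitor), compound 1 gives 2390 nM, the highest of the two numbers measured; compound 2 gives 8 nM, a far lower number, and the gap between the two lies well beyond the scatter. Both carry the same selenocyanate-bearing core.

Compound 3, `COc1ccc(N(C)c2nc(C)nc3ccccc23)cc1OCCCCC[Se]C#N`, has not yet been measured. It differs from compound 1 in one place: a group of 9 heavy atoms (6 carbon, 1 nitrogen, 1 oxygen, 1 selenium; no ring) in place of a group of 8 heavy atoms (4 carbon, 1 nitrogen, 2 oxygen, 1 selenium; no ring), on an aromatic carbon The rest of compound 1 is kept.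

Going by the values given here, no step between measured compounds bears on this exact change, so the expectation rests on compound 1 alone. Compound 3 is expected to stay near compound 1, with at most a small move toward a lower number, a step from compound 1 to compound 3 estimated at a 1.6-fold lower number from compound 1 to compound 3 (0.20 log units; within the scatter) in this assay, which is at the edge of the scatter. The estimate for compound 3 in this assay is 1500 nM, with a range from 400 nM to 6000 nM.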

Compound 3, half-maximal inhibitory concentration: 3560 nM
Compound 3: middle estimate off by 2.4-fold (0.38 log units), on the low side; measured number inside the range.
By their numbers in this assay, from the lowest: compound 2; then compounds 1 and 3 (each within the scatter of the next).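

In this assay, placing the group of 9 heavy atoms in place of the group of 8 heavy atoms, on an aromatic carbon ortho to a methoxy group, gives a 1.5-fold higher number from compound 1 to compound 3 (0.17 log units; within the scatter). This position therefore tolerates the exchange without a reading beyond the scatter, even though the double bond outside aromatic rings and one hydrogen-bond acceptor are lost and the selenium-bearing chain is built differently. Nothing measured here explains why the two groups read alike.

Still open, as far as these compounds go, is whether a shorter or longer chain, or an amine or a carboxylic acid in place of the selenocyanate end, would separate from these two groups at this position. Also open, from the compounds shown here alone, is whether the same exchange reads alike with a hydrogen in place of the methoxy group.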